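Replacing the pyridine with phenyl on the shared core

A few compounds are considered here, and "the series" means these few. Any claim that something is new, unique, unknown or untested is made for them only; others in the source may bear on it.

In an assay on MCF7 cells for inhibition of Serine-protein kinase ATM (Homo sapiens), read by immunofluorescence, with a stated time of 1 h (on this read-out higher numbers stand for weaker inhibition and lower numbers for stronger inhibition), compound 1 `COc1ccc(-c2nc(N)n(-c3ncnc4ccccc34)n2)cc1` gives only a limit of the assay, > 40000 nM. Compound 2 `COc1cc2ncnc(-n3nc(-c4cccnc4)nc3N)c2cc1OC` gives 15000 nM. Compound 3 `COc1cc2ncnc(-n3nc(-c4ccncc4)nc3N)c2cc1OC` gives 5000 nM, the lowest of the two numbers obtained so far. Among the compounds with values here, the step of a 3.0-fold lower number from compound 2 to compound 3 (0.48 log units; beyond the scatter) is modest in size, and it is the only measured step that touches this ring. Compound 4 `COc1cc2ncnc(-n3nc(-c4ccccc4)nc3N)c2cc1OC` differs from compound 3 by phenyl in place of pyridin-4-yl on an aromatic carbon, so the ring nitrogen is lost altogether rather than shifted. Within the data shown here, no measured step removes that nitrogen, so the expectation leans on the modest size of the one known step and allows for a somewhat weaker result. Compound 4 is therefore expected to come out at 9000 nM, within 3000 nM to 30000 nM. The expected step is a 1.8-fold higher number from compound 3 to compound 4 (0.26 log units; within the scatter).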

Compound 4, half-maximal inhibitory concentration: 2000 nM
The estimate for compound 4 lay 4.5-fold (0.65 log units) above the measured number; measured number outside the range, below it.
By their numbers in this assay, from the lowest: compound 4; then compound 3; then compound 2. At a limit, above all of these: compound 1.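

A ring nitrogen at this position is not needed for a low number in this assay: phenyl in place of pyridin-4-yl gives a 2.5-fold lower number from compound 3 to compound 4 (0.40 log units; beyond the scatter) and phenyl in place of pyridin-3-yl gives a 7.5-fold lower number from compound 2 to compound 4 (0.88 log units; beyond the scatter). Within the data shown here, the earlier compounds showed only that moving the nitrogen changes the number, whereas these steps show that removing it lowers the number further than either pyridine reaches. Nothing shown here accounts for this order.

As far as these compounds go, whether a phenyl carrying an amine or a carboxylic acid would lower the number further remains open. So does whether a saturated ring such as piperidine could take the place of phenyl.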